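The source may hold more compounds than are shown below. What is called first, only, known or untested is meant among the compounds shown, and "the series" means these compounds.

Working notes on the series in a functional assay on HepG2 cells (Homo sapiens) for antiproliferative activity, read by MTT assay, with a stated time of 48 h; a lower number here means a stronger inhibitor, a higher number a weaker inhibitor. Compound 1 `Clc1cccc(CSc2nnc(-c3cnccn3)n2-c2ccccc2)c1` gives 19600 nM and compound 2 `Brc1ccc(CSc2nnc(-c3cnccn3)n2-c2ccccc2)cc1` gives 11400 nM. Within the data shown here, these are the only two numbers so far, and compound 2 stands within the scatter of compound 1.

Compound 3 `Fc1cccc(F)c1CSc1nnc(-c2cnccn2)n1-c1ccccc1` has not yet been measured. The structural change from compound 2 is 2,6-difluorophenyl in place of 4-bromophenyl on a saturated chain carbon bound to a sulfur.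

Among the measured compounds shown here, one measured step bears on this change: a 1.7-fold lower number from compound 1 to compound 2 (0.24 log units; within the scatter), which came with 4-bromophenyl in place of 3-chlorophenyl at the same place. That step stays within the scatter. For the measured compounds named here, no measured compound carries 2,6-difluorophenyl, so the data offer no direct precedent and no firm direction. No step beyond the scatter is expected in this assay, and the range is kept wide for that lack of precedent. The expected step is a 1.3-fold higher number from compound 2 to compound 3 (0.12 log units; within the scatter). For compound 3 the estimated value is 15000 nM, with an expected range from 6000 nM to 40000 nM.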

Compound 3, half-maximal inhibitory concentration: 22600 nM
Compound 3: the middle estimate sits 1.5-fold (0.18 log units) below what was measured; measured number inside the range.
By their numbers in this assay, from the lowest: compounds 2, 1 and 3 (each within the scatter of the next).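

In this assay, the change to 2,6-difluorophenyl extends the earlier comparison from two singly halogenated rings to one carrying two fluorine atoms, and both new steps stay within the scatter: a 2.0-fold higher number from compound 2 to compound 3 (0.30 log units; within the scatter) and a 1.2-fold higher number from compound 1 to compound 3 (0.06 log units; within the scatter). Across 3-chlorophenyl, 4-bromophenyl and 2,6-difluorophenyl on a saturated chain carbon bound to a sulfur, the three compounds therefore show no separable difference, although the halogen, its count and its placement on the ring all vary. No measurement available here bears on the interpretation of this result.

As far as these compounds go, all three groups remain halogen-substituted phenyl rings on the same one-carbon link to sulfur, so it remains open whether an amine or a carboxylic acid on the ring, or a longer chain between the sulfur and the ring, would produce a step beyond the scatter. All three compounds also share one core, which leaves open whether the same lack of separation would hold on any other core.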